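The source may hold more compounds than are shown below. What is called first, only, known or untested is meant among the compounds shown, and "the series" means these compounds.

Going by the values given here, compound 1, with the structure `Nc1nc2cc(-c3nn(CCCCCCCCCC(=O)NO)c4ncnc(N)c34)ccc2o1`, sits at the bottom of the three numbers so far in an assay on isolated protein for inhibition of protein deacetylase HDAC6 (Homo sapiens), with a stated time of 15 min, tested at 1 uM (on this read-out lower numbers stand for less inhibition and higher numbers for more inhibition at the one concentration tested (going by the name of the read-out)), where compound 1 gives 98.2%. Its companions are compound 2, `Nc1nc2cc(-c3nn(CCCCCCCCC(=O)NO)c4ncnc(N)c34)ccc2o1`, which in this assay gives 99%, and compound 3, `CNC(=O)CCCCCCCn1nc(-c2ccc3oc(N)nc3c2)c2c(N)ncnc21`, which gives 99.1%. The shortening from compound 1 to compound 2 moved the number by a number 0.8 percentage points higher from compound 1 to compound 2 (within the scatter), the change from compound 1 to compound 3 by a number 0.9 percentage points higher from compound 1 to compound 3 (within the scatter), and from compound 2 to compound 3 by a number 0.1 percentage points higher from compound 2 to compound 3 (within the scatter); all three lie within the scatter, so the chain length and the end group have so far left the read-out unmoved near its ceiling.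

Compound 4, `Nc1nc2cc(-c3nn(CCCCCCC(=O)NO)c4ncnc(N)c34)ccc2o1`, differs from compound 1 as follows: hydroxycarbamoyl in place of 3-(hydroxycarbamoyl)propyl on a saturated chain carbon, six bonds along the chain from an aromatic nitrogen. This is a larger cut of the same chain than the step from compound 1 to compound 2, and nothing measured speaks against it, yet nothing measured tests a chain this short either. He therefore expects a step of a number 3.2 percentage points lower from compound 1 to compound 4 (within the scatter), no more than the scatter, with some room below for a shorter chain. Compound 4 is estimated at 95%, between 82% and 100%.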

Compound 4, a percentage reported as inhibition, at one concentration (the size of the read-out at that concentration, not a potency): 99%
Compound 4: the middle estimate sits 4 percentage points below what was measured, within the range that was stated.
By their numbers in this assay, from the lowest: compounds 1, 2, 4 and 3 (each within the scatter of the next).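

Compound 4 extends the test to a much shorter chain: in this assay, replacing 3-(hydroxycarbamoyl)propyl with hydroxycarbamoyl at this place gives a number 0.8 percentage points higher from compound 1 to compound 4 (within the scatter), and the comparison with the next chain length gives no change at the digits printed from compound 2 to compound 4 (within the scatter). The same place also shows no separation from the methylcarbamoyl compound, with a number 0.1 percentage points lower from compound 3 to compound 4 (within the scatter), so this end-group change and the chain cut both leave the read-out near its ceiling at the single concentration tested. No supporting measurement bears on why the read-out holds across these changes.

Still open, going by these compounds, is whether a chain shorter than that of compound 4 would lower the read-out. On these data alone, it is also open whether a carboxylic acid or an amine at the chain end would do so.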